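The source may hold more compounds than are shown below. What is called first, only, known or untested is meant among the compounds shown, and "the series" means these compounds.

Compound 1: `C=C1/C=C/C(=O)/C(CO)=C\C[C@](C)(CCC=C(C)C)/C=C/[C@H]1OC(=O)C=C(C)C`, 2810 nM
Compound 2: `CC(C)=CCC[C@]1(C)/C=C/[C@@H](OC(=O)C=C(C)C)[C@](C)(O)/C=C/C(=O)/C(C(=O)O)=C\C1`, > 10000 nM
Compound 3: `CC(C)=CCC[C@]1(C)/C=C/[C@@H](OC(=O)C=C(C)C)[C@](C)(O)/C=C/C(=O)/C(C[Si](c2ccccc2)(c2ccccc2)C(C)(C)C)=C\C1`, 14400 nM

Of the compounds shown here, three built on a shared core have been tested in a functional assay on HL-60 cells (Homo sapiens) for antiproliferative activity, read by MTT assay, with a stated time of 48 h; a lower number here means a stronger inhibitor, a higher number a weaker inhibitor. Compound 1, `C=C1/C=C/C(=O)/C(CO)=C\C[C@](C)(CCC=C(C)C)/C=C/[C@H]1OC(=O)C=C(C)C`, gives 2810 nM in this assay, and compound 3, `CC(C)=CCC[C@]1(C)/C=C/[C@@H](OC(=O)C=C(C)C)[C@](C)(O)/C=C/C(=O)/C(C[Si](c2ccccc2)(c2ccccc2)C(C)(C)C)=C\C1`, gives 14400 nM. For compound 2, `CC(C)=CCC[C@]1(C)/C=C/[C@@H](OC(=O)C=C(C)C)[C@](C)(O)/C=C/C(=O)/C(C(=O)O)=C\C1`, the result in this assay is only a limit, > 10000 nM, so no exact number is known for it. Compound 2 is the one that sits at the limit of > 10000 nM in this assay, at which 1 of the 3 values shown sits, which makes any step from it hard to size.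

Compound 4, `CC(C)=CCC[C@]1(C)/C=C/[C@@H](OC(=O)C=C(C)C)[C@](C)(O)/C=C/C(=O)/C(C(=O)N(C)C)=C\C1`, differs from compound 2 in a single place: dimethylamino in place of hydroxy on a carbonyl carbon. Among the compounds with values here, no two of the measured compounds differ from each other in one place, so there is no measured step to lean on here.

On these data alone, compound 4 is expected to be a somewhat stronger inhibitor than compound 2, a step of an at least 1.2-fold lower number from compound 2 to compound 4 (0.09 log units; that floor lies within the scatter) toward lower numbers, though the limit for compound 2 leaves its true size open. Compound 4 is therefore estimated at 8000 nM, with a likely range from 2500 nM to 25000 nM.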

Compound 4, half-maximal inhibitory concentration: 3340 nM
Compound 4: middle estimate off by 2.4-fold (0.38 log units), on the high side; the measured number falls inside the stated range.
By their numbers in this assay, from the lowest: compounds 1 and 4 (each within the scatter of the next); then compound 3.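

Within the data shown here, changing carboxy to dimethylcarbamoyl on the carbonyl carbon gives the first measured step at this position in this assay: an at least 2.9-fold lower number from compound 2 to compound 4 (0.47 log units; beyond the scatter). Among these compounds, until now no two compounds differed in one place, so this is the first evidence that a change here alone moves the number beyond the scatter. The printed figure is a floor and not an exact size because compound 2 has only a limit of the assay: the limit of > 10000 nM in this assay, at which 1 of the 4 values shown sits.

The compounds shown leave open how a primary amide, a methyl ester or a diethylcarbamoyl group would read at this same carbonyl carbon in this assay. They also leave open whether the dimethyl groups themselves matter, or whether any amide here would give a similar step.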